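This account rests on a few compounds, and the source may have more. Where it says the series, first, only, none or still open, it means among the compounds named here.

Compound 1 `FC(F)(F)c1ccc(NC2=NCCC3(CCCCC3)S2)cc1`: 77600 nM
Compound 2 `CCc1ccc(NC2=NCCC3(CCCCC3)S2)cc1`: 11700 nM

Both numbers come from a functional assay on a subcellular fraction from brain (Rattus norvegicus) for inhibition, read by scintillation counting, with a stated time of 5 min; on this read-out lower numbers stand for stronger inhibition and higher numbers for weaker inhibition. Within the data shown here, compound 2 has the lowest number of the two measured compounds; its nearest neighbour is compound 1, and the only step known so far runs between them: a 6.6-fold lower number from compound 1 to compound 2 (0.82 log units; beyond the scatter). Compound 3 `COc1ccc(NC2=NCCC3(CCCCC3)S2)cc1` shares the same core and differs from compound 2 in one place: methoxy in place of ethyl on an aromatic carbon. Among the measured compounds shown here, no measured step covers a swap of ethyl for methoxy, so the one known step tells only that a change at this aromatic carbon can shift the result in this assay by a modest amount. Compound 3 is therefore expected to land close to compound 2, with a step of a 1.0-fold higher number from compound 2 to compound 3 (0.01 log units; within the scatter) that may well stay within the scatter. The estimate for compound 3 in this assay is 12000 nM, with a range from 3500 nM to 40000 nM.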

Compound 3, half-maximal inhibitory concentration in the brain assay: 85100 nM
The estimate for compound 3 lay 7.1-fold (0.85 log units) below the measured number, outside the stated range (above it).
By their numbers in the brain assay, from the lowest: compound 2; then compounds 1 and 3 (each within the scatter of the next).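

Ethyl and methoxy both count 2 heavy atoms, yet in the brain assay the swap gives a 7.3-fold higher number from compound 2 to compound 3 (0.86 log units; beyond the scatter), so at this aromatic carbon the result is not set by the count of heavy atoms alone. Methoxy and trifluoromethyl cannot be told apart here, with a 1.1-fold higher number from compound 1 to compound 3 (0.04 log units; within the scatter), which leaves the ethyl of compound 2 as the only one of these three groups that gives stronger inhibition. In a physicochemical assay for lipophilicity, measured as octanol-water partition, at pH 7.4 (a higher number here means a more lipophilic compound, a lower number a more polar compound), compound 2 gives 2.31 and compound 3 gives 0.8, so the weaker inhibition of compound 3 goes together with lower lipophilicity in this pair: the measured distribution coefficient of compound 2, 2.31, and of compound 3, 0.8, a number 1.51 log units lower (beyond the scatter)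

One pair cannot show whether that link holds more widely or is a cause. The compounds shown also leave open whether a longer chain such as propyl, or an amine, on this aromatic carbon would give stronger inhibition than ethyl.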